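Dropping the methoxy from the salicylanilide aniline ring

The source may report more compounds than this note shows. Statements on the series, on what has been measured and on what is new or still open speak of the compounds shown alone.

Of the compounds shown here, three have numbers so far. Compound 1 `NC(=O)c1ccc(O)c(C(=O)Nc2cc(C(F)(F)F)cc(C(F)(F)F)c2)c1` reaches only the limit of an assay for inhibition of transmembrane protease serine 4 (Homo sapiens), read by fluorescence; a higher number here means a weaker inhibitor, a lower number a stronger inhibitor; its value is the limit > 100000 nM and not a number (the limit of > 100000 nM in this assay, at which 1 of the 3 values shown sits). Compound 2 `O=C(Nc1cc(Cl)cc(Cl)c1)c1cc(Cl)ccc1O` gives 19000 nM in this assay. Compound 3 `COc1cc(NC(=O)c2cc(Cl)ccc2O)cc(C(F)(F)F)c1` gives 16000 nM in this assay, the lowest of the two numbers, with compound 2 sitting within the scatter of it, so no order between these two is claimed.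

Compound 4 `O=C(Nc1cccc(C(F)(F)F)c1)c1cc(Cl)ccc1O` is compound 3 with hydrogen in place of methoxy on an aromatic carbon. The aniline ring keeps its trifluoromethyl group and loses only the methoxy. Compound 2, which also carries two small substituents on that ring and nothing else, lies within the scatter of compound 3, so the substitution pattern on this ring has not moved the number beyond the scatter among the compounds with numbers. The step from compound 3 to compound 4 is therefore expected to be a 1.3-fold higher number from compound 3 to compound 4 (0.10 log units; within the scatter), with no direction beyond the scatter.

Compound 4 is estimated at 20000 nM in this assay, with a range from 7000 nM to 60000 nM.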

Compound 4, half-maximal inhibitory concentration: 13000 nM
Beside the measured number, compound 4's estimate is 1.5-fold (0.19 log units) above it; the range from low to high includes it.
By their numbers in this assay, from the lowest: compounds 4, 3 and 2 (each within the scatter of the next). At a limit, above all of these: compound 1.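

The series now has its first step at a single place in this assay: hydrogen in place of methoxy gives a 1.2-fold lower number from compound 3 to compound 4 (0.09 log units; within the scatter). On this aromatic carbon, then, the methoxy can be removed without the number leaving the scatter, and the ring with trifluoromethyl as its only substituent still gives a measurable number in this assay. Nothing among the data shown bears on the reason for this step.

Still open, going by these compounds, is whether any group on this carbon moves the number beyond the scatter, for instance an amine, a carboxylic acid or a longer alkoxy chain. Also open, on these data alone, is what the trifluoromethyl group itself contributes, which only a pair differing at that place, such as hydrogen in its stead, could show.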